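Swapping the Methylpyrimidine for a Hydroxymethylpyridine

The source may hold more compounds than are shown below. What is called first, only, known or untested is meant among the compounds shown, and "the series" means these compounds.

Compound 1, `Cc1ccc(-c2ccc(Cl)c(C(=O)NCC3(O)CCCCCC3)c2)nn1`: 18 nM
Compound 2, `Cc1cnc(-c2ccc(Cl)c(C(=O)NCC3(O)CCCCCC3)c2)cn1`: 22 nM
Compound 3, `Cc1cnc(-c2ccc(Cl)c(C(=O)NCC3(O)CCCCCC3)c2)nc1`: 8 nM

All three share one core and differ only in the six-membered aromatic ring attached to it. In a functional assay on HEK293 cells for antagonist activity at P2X purinoceptor 7 (Homo sapiens) (a higher number here means a weaker inhibitor, a lower number a stronger inhibitor), compound 1 gives 18 nM, compound 2 gives 22 nM, and compound 3 gives 8 nM. Compound 3 holds the lowest number: the steps of a 2.3-fold lower number from compound 1 to compound 3 (0.35 log units; beyond the scatter) and a 2.8-fold lower number from compound 2 to compound 3 (0.44 log units; beyond the scatter) both exceed the scatter, so it is the strongest inhibitor of the three, while a 1.2-fold higher number from compound 1 to compound 2 (0.09 log units; within the scatter) lies within the scatter.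

Compound 4, `O=C(NCC1(O)CCCCCC1)c1cc(-c2ccc(CO)cn2)ccc1Cl`, carries a new ring: 5-(hydroxymethyl)pyridin-2-yl in place of 5-methylpyrimidin-2-yl on an aromatic carbon. The measured steps bear on this only in part: each exchanged one methyl-bearing heteroaromatic ring for another, and all stayed within about a modest range. None tested a hydroxymethyl group in place of the methyl, so that part of the change is uncharted. A modest weakening is therefore expected, roughly a 2.0-fold higher number from compound 3 to compound 4 (0.30 log units; within the scatter) in this assay. Compound 4 is estimated at 16 nM, with a likely range from 5 nM to 50 nM.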

Compound 4, half-maximal inhibitory concentration: 17 nM
The estimate for compound 4 lay 1.1-fold (0.03 log units) below the measured number; low and high end bracket the measured number.
By their numbers in this assay, from the lowest: compound 3; then compounds 4, 1 and 2 (each within the scatter of the next).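

In this assay, the switch to a ring with a hydroxymethyl group gives up the lead held by compound 3 (a 2.1-fold higher number from compound 3 to compound 4 (0.33 log units; beyond the scatter)). Among these compounds, it still leaves a result level with the two other methyl-bearing rings (a 1.3-fold lower number from compound 2 to compound 4 (0.11 log units; within the scatter); a 1.1-fold lower number from compound 1 to compound 4 (0.02 log units; within the scatter)), so this position can hold a ring carrying a hydrogen-bond donor, which no earlier compound had, without a loss beyond compounds 1 and 2. Nothing measured here offers an explanation for these numbers.

Going by these compounds, this swap changes two things at once, the ring nitrogens and the methyl becoming hydroxymethyl, so their separate shares remain open, and 5-methylpyridin-2-yl would sit between the two. Also open, on these data alone, is how an aminomethyl group or a carboxylic acid would fare on the same ring.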